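The source may hold more compounds than are shown below. What is called first, only, known or untested is meant among the compounds shown, and "the series" means these compounds.

Working notes on the series. The shared core of compound 1 `Cc1nc2c3ccccc3ccc2c2nc3c(ccc4ccccc43)c(-c3cccc([N+](=O)[O-])c3)c12` carries a 3-nitrophenyl group; in a functional assay on HCT-116 cells (Homo sapiens) for cytotoxicity, read by MTT assay, with a stated time of 48 h (a lower number here means a stronger inhibitor, a higher number a weaker inhibitor), compound 1 gives 13200 nM. Compound 2 `Cc1nc2c3ccccc3ccc2c2nc3c(ccc4ccccc43)c(C)c12` carries methyl in the same place. For compound 2 this assay reports only a limit, > 80000 nM, and no number. Compound 3 `Cc1nc2c3ccccc3ccc2c2nc3c(ccc4ccccc43)c(-c3nccnc3N)c12` carries 3-aminopyrazin-2-yl and in this assay gives 3560 nM, the lowest of the two numbers shown; the nearest is compound 1, and the step was a 3.7-fold lower number from compound 1 to compound 3 (0.57 log units; beyond the scatter). From methyl the step was an at least 22-fold lower number from compound 2 to compound 3 (1.35 log units; beyond the scatter), so an aromatic ring in this position matters more than which aromatic ring it is.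

Compound 4 `Cc1nc2c3ccccc3ccc2c2nc3c(ccc4ccccc43)c(-c3ccccc3N)c12` differs from compound 3 by 2-aminophenyl in place of 3-aminopyrazin-2-yl on an aromatic carbon. The change keeps an aromatic ring bearing an amine, so the step is expected to resemble the modest one from compound 1 to compound 3 rather than the large one from compound 2, and is estimated as a 1.8-fold higher number from compound 3 to compound 4 (0.26 log units; within the scatter), a somewhat weaker inhibitor. For compound 4 the expected value in this assay is 6500 nM, with a range from 2500 nM to 20000 nM.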

Compound 4, half-maximal inhibitory concentration: 4760 nM
Compound 4: the middle estimate sits 1.4-fold (0.14 log units) above what was measured; the range from low to high includes it.
By their numbers in this assay, from the lowest: compounds 3 and 4 (each within the scatter of the next); then compound 1. At a limit, above all of these: compound 2.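

With the amine kept, replacing the ring with hetero atoms of 3-aminopyrazin-2-yl by a ring of carbon only gives a 1.3-fold higher number from compound 3 to compound 4 (0.13 log units; within the scatter) in this assay, so these ring hetero atoms are not needed for the values seen here. The 2-aminophenyl group also separates from 3-nitrophenyl, with a 2.8-fold lower number from compound 1 to compound 4 (0.44 log units; beyond the scatter), so compound 1 stands apart from both amine-bearing compounds, and a carbon-only ring can reach the level of compound 3. Compound 2 is read only as a limit, so an at least 16-fold lower number from compound 2 to compound 4 (1.22 log units; beyond the scatter) is a bound and not a measured size: the limit of > 80000 nM in this assay, at which 1 of the 4 values shown sits.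

Open, going by these compounds, is whether the amine itself or its place on the ring sets these values, a question that phenyl, 3-aminophenyl or 2-hydroxyphenyl would address. Also open, on these data alone, is whether a non-aromatic group larger than methyl, such as a cyclohexyl ring or a longer chain, would behave like methyl or like the aromatic rings.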